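Thiophen-3-yl for Methyl: Expected Cell Tolerance of Compound 4

The compounds below may be only part of what the source reports. "The series", "measured", "known", "first", "only" and "open" are said of these compounds alone.

Measured so far:
- compound 1, `Nc1nc(Cl)c(-c2nc3ccc(Cl)cc3s2)c(N[C@@H]2C[C@H](CO)[C@@H](O)[C@H]2O)n1`: 16000 nM
- compound 2, `Nc1ncc(-c2nc3ccccc3s2)c(N[C@@H]2C[C@H](CO)[C@@H](O)[C@H]2O)n1`: > 25000 nM
- compound 3, `CCNc1nc(C)c(-c2nc3ccccc3s2)c(N[C@@H]2C[C@H](CO)[C@@H](O)[C@H]2O)n1`: 12000 nM

Of the compounds shown here, three on a shared core have been tested in an ADME assay on cells (Homo sapiens) for cytotoxicity, read by polymerase chain reaction, with a stated time of 3 days; a lower number here means that less compound is tolerated, a higher number that more compound is tolerated. Compound 3 gives 12000 nM, the lowest of the two plain numbers; compound 1, with 16000 nM, sits within the scatter of it, so the two cannot be told apart. For compound 2 the assay returned only a limit, > 25000 nM, not a number (the limit of > 25000 nM in this assay, at which 1 of the 3 values shown sits).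

The unmeasured compound 4 is `Cc1nc(NCc2ccsc2)nc(N[C@@H]2C[C@H](CO)[C@@H](O)[C@H]2O)c1-c1nc2ccccc2s1`. Compared with compound 3 it carries thiophen-3-yl in place of methyl on a saturated chain carbon bound to a nitrogen on an aromatic ring. Read one bond further out, an ethylamino becomes a ((thiophen-3-yl)methyl)amino on the core.

Among the measured compounds shown here, no measured pair shows a change of exactly this kind, so the expected step rests on the structural change alone. A modest shift toward a lower number in this assay is expected for compound 4, on the order of a 1.5-fold lower number from compound 3 to compound 4 (0.18 log units; within the scatter), though a result within the scatter of compound 3 would not surprise. Compound 4 is therefore estimated at 8000 nM, with a likely range from 3000 nM to 25000 nM.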

Compound 4, half-maximal cytotoxic concentration: 6000 nM
Beside the measured number, compound 4's estimate is 1.3-fold (0.12 log units) above it; the measured number falls inside the stated range.
By their numbers in this assay, from the lowest: compounds 4, 3 and 1 (each within the scatter of the next, the first and the last beyond it). At a limit, above all of these: compound 2.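

Among the compounds shown here, this is the first pair on the shared core that differs in one place, so it gives the first direct reading of a change at this position: in this assay, putting thiophen-3-yl in place of methyl on a saturated chain carbon bound to a nitrogen on an aromatic ring gives a 2.0-fold lower number from compound 3 to compound 4 (0.30 log units; within the scatter). That step lies within the usual scatter of repeated measurements, so compound 3 and compound 4 cannot be told apart here, and this position accepts a five-membered aromatic ring containing sulfur with no change that this measurement can resolve. No measurement shown here offers an explanation for this step.

For the compounds shown here, with only one such pair, it remains open whether other groups on that saturated chain carbon, such as a phenyl ring, an amine, a carboxylic acid or a longer chain, would also stay within the scatter of compound 3. Going by these compounds, it is also open whether the same swap would give a similar step on a core carrying other groups, such as the core of compound 1.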